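The source may report more compounds than this note shows. Statements on the series, on what has been measured and on what is new or still open speak of the compounds shown alone.

Compound 1, `O=C1C=C(NCc2ccccc2)C(=O)c2c1nc1n2[C@H]2OC[C@@H](O)[C@H]2OC1`, in a functional assay on MCF7 cells (Homo sapiens) for inhibition, read by sulforhodamine B assay (a lower number here means a stronger inhibitor, a higher number a weaker inhibitor), gives only a limit, > 8000 nM.
Compound 2, `COc1ccc(NC2=CC(=O)c3nc4n(c3C2=O)[C@H]2OC[C@@H](O)[C@H]2OC4)cc1`, in this assay gives 5420 nM.
Compound 3, `CCOc1ccccc1NC1=CC(=O)c2nc3n(c2C1=O)[C@H]1OC[C@@H](O)[C@H]1OC3`, in this assay gives only a limit, > 4000 nM.

Compound 3 therefore stands on a limit rather than a number, and two of the three values shown are limits (the limit of > 4000 nM in this assay, at which 1 of the 3 values shown sits, and (the limit of > 8000 nM in this assay, at which 1 of the 3 values shown sits)). Compound 4, `COc1ccccc1NC1=CC(=O)c2nc3n(c2C1=O)[C@H]1OC[C@@H](O)[C@H]1OC3`, differs from compound 3 by hydrogen in place of methyl on a saturated chain carbon bound to an oxygen on an aromatic ring. For the measured compounds named here, no measured step touches this part of the molecule: the step of an at least 1.4-fold lower number from compound 1 to compound 2 (0.16 log units; that floor lies within the scatter) swaps a different group, and the steps a step that the two limits leave unreadable from compound 1 to compound 3 and a step that the limit leaves unreadable from compound 2 to compound 3 cannot be sized. The change is small, so no step beyond the scatter is expected in this assay, and the step from compound 3 to compound 4 is expected to be a step that the limit leaves unreadable from compound 3 to compound 4. Compound 4 is estimated at 6000 nM, between 2500 nM and 15000 nM, and may again appear only as a limit.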

Compound 4, half-maximal inhibitory concentration: > 4000 nM
Compound 4: no number, only a limit; the forecaster's own chance of this, stated with the estimate: 60%; the middle value does not contradict the limit.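

In this assay compound 4 gives only a limit, > 4000 nM. Its steps to compound 1, compound 2 and compound 3 therefore cannot be read. Still open, as far as these compounds go, is whether ethoxy to methoxy changes the result at all, and where compound 1, compound 3 and compound 4 truly stand against compound 2.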